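The source may report more compounds than this note shows. Statements on the series, on what has been measured and on what is new or still open speak of the compounds shown alone.

Compound 1 `O=C(/C=C/c1ccc(OCc2cn(Cc3ccccc3)nn2)cc1)c1ccc(Br)cc1` and compound 2 `O=C(/C=C/c1ccc(OCc2cn(Cc3cccc(Br)c3)nn2)cc1)c1ccc(Br)cc1` share one core; compound 2 differs from compound 1 by bromo in place of hydrogen on an aromatic carbon. In a functional assay on A549 cells (Homo sapiens) for inhibition, read by MTT assay, with a stated time of 48 h, tested at 10 uM (a higher number here means more inhibition of growth at the concentration tested, a lower number less inhibition of growth), compound 1 gives 34%, and compound 2 gives 44%; the step of a number 10 percentage points higher from compound 1 to compound 2 (within the scatter) lies within the scatter of repeated measurements, so the two readings cannot be told apart. Compound 3 `O=C(/C=C/c1ccc(OCc2cn(Cc3ccccc3)nn2)cc1)c1ccc([N+](=O)[O-])cc1` has a different core: it differs from compound 1 by nitro in place of bromo on an aromatic carbon. In this assay compound 3 is reported as "not active" (no number reported), with no single number. Compound 4 `O=C(/C=C/c1ccc(OCc2cn(Cc3ccccc3Br)nn2)cc1)c1ccc([N+](=O)[O-])cc1` has the core of compound 3 and differs from it by bromo in place of hydrogen on an aromatic carbon, the same kind of change as from compound 1 to compound 2, but here the bromo sits ortho to a large group rather than meta to it. Because the step of a number 10 percentage points higher from compound 1 to compound 2 (within the scatter) stayed within the scatter, and because compound 3 gives "not active" (no number reported), adding bromo is expected to move the reading little. Compound 4 is therefore expected to give 15%, with a range estimated from 0% to 35%.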

Compound 4, percent growth inhibition at one concentration: 42%
For compound 4 the middle estimate is 27 percentage points below the measured one; measured number outside the range, above it.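

No step can be read between compound 3 and compound 4: in this assay compound 4 gives 42% while compound 3 is reported as "not active" (no number reported) and so offers no figure to compare. The compounds shown leave open what 2-bromobenzyl in place of benzyl does on the core of compound 1. Nothing given here explains the reading of compound 4.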